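Meta Substituent Swap on the Benzylamine Arm

The source may hold more compounds than are shown below. What is called first, only, known or untested is meant among the compounds shown, and "the series" means these compounds.

Measured so far, in a functional assay on BE(2)-C cells (Homo sapiens) for inhibition, read by MTT assay, with a stated time of 72 h; a lower number here means a stronger inhibitor of growth, a higher number a weaker inhibitor of growth:
compound 1 `COc1ccc(CNCCCNS(=O)(=O)c2cc(C(F)(F)F)cc(C(F)(F)F)c2)cc1OC` gives 3600 nM
compound 2 `O=S(=O)(NCCCNCc1ccccc1)c1cc(C(F)(F)F)cc(C(F)(F)F)c1` gives 12000 nM
compound 3 `O=S(=O)(NCCCNCc1cccc(Cl)c1)c1cc(C(F)(F)F)cc(C(F)(F)F)c1` gives 6900 nM

Compound 3 sits second highest of the three numbers; its nearest neighbour is compound 2 via a 1.7-fold lower number from compound 2 to compound 3 (0.24 log units; within the scatter), and the other gap is a 1.9-fold higher number from compound 1 to compound 3 (0.28 log units; within the scatter), both within the scatter. Compound 4 `COc1cccc(CNCCCNS(=O)(=O)c2cc(C(F)(F)F)cc(C(F)(F)F)c2)c1` differs from compound 3 by methoxy in place of chloro on an aromatic carbon. Within the data shown here, the only step beyond the scatter in this assay is a 3.3-fold higher number from compound 1 to compound 2 (0.52 log units; beyond the scatter), where both methoxy groups enter together; a single methoxy has not been separated out. The step from compound 3 to compound 4 is therefore expected to stay within the scatter, if anything slightly lower: a 1.4-fold lower number from compound 3 to compound 4 (0.14 log units; within the scatter). Compound 4 is estimated at 5000 nM, with a range of 2500 nM to 10000 nM.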

Compound 4, concentration for 50% growth inhibition: 4500 nM
Compound 4: middle estimate off by 1.1-fold (0.05 log units), on the high side; the measured number falls inside the stated range.
By their numbers in this assay, from the lowest: compounds 1, 4, 3 and 2 (each within the scatter of the next, the first and the last beyond it).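

A single methoxy on the 3-methoxyphenyl ring is enough for a step beyond the scatter in this assay: a 2.7-fold lower number from compound 2 to compound 4 (0.43 log units; beyond the scatter). The second methoxy of the 3,4-dimethoxyphenyl group adds no readable change, with a 1.3-fold higher number from compound 1 to compound 4 (0.10 log units; within the scatter), and methoxy and chloro at this place cannot be told apart, with a 1.5-fold lower number from compound 3 to compound 4 (0.19 log units; within the scatter). No measurement on hand accounts for these steps.

Open, from the compounds shown here alone, is whether a hydroxyl or a nitrile on this aromatic carbon would separate from methoxy and chloro in this assay.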